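Replacing One Ring Substituent on Compound 2

The source may hold more compounds than are shown below. What is called first, only, known or untested is meant among the compounds shown, and "the series" means these compounds.

Measured so far:
compound 1, `CC(=O)NCCC(CC(=O)Nc1ccc(C)cc1C)c1nnc(CCCC(C)C)n1C1CC1`: 39%
compound 2, `Cc1ccc(NC(=O)C[C@H](CCC(=O)O)c2noc(-c3ncc(CC(C)C)s3)c2C2CC2)c(Cl)c1`: 82%

In an ADME assay on microsomes from liver (Homo sapiens) for metabolic stability, with a stated time of 60 min (on this read-out higher numbers stand for a more stable compound and lower numbers for a less stable compound), compound 2 gives the higher of the two numbers; compound 1 gives a value lower by a margin well beyond the usual scatter of this measurement. Compound 3, `Cc1ccc(NC(=O)C[C@H](CCC(=O)O)c2noc(-c3cc(CC(C)(C)C)on3)c2C2CC2)c(Cl)c1`, differs from compound 2 in one place: 5-neopentyl-1,2-oxazol-3-yl in place of 5-isobutyl-1,3-thiazol-2-yl on an aromatic carbon. Everything else in the two structures, including the cyclopropyl group on the shared core, is the same. Among the compounds with values here, no measured pair in this set shows what such an exchange does, so the expectation rests on compound 2 alone, and a wide range is the honest answer. In this assay a modest downward step, perhaps somewhat beyond the scatter, is expected: a number 12 percentage points lower from compound 2 to compound 3 (beyond the scatter). Compound 3 is therefore estimated at 70% in this assay, with a range from 45% to 90%.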

Compound 3, percent of the compound remaining: 84%
For compound 3 the middle estimate is 14 percentage points below the measured one; measured number inside the range.
By their numbers in this assay, from the lowest: compound 1; then compounds 2 and 3 (each within the scatter of the next).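

In this assay, 5-neopentyl-1,2-oxazol-3-yl in place of 5-isobutyl-1,3-thiazol-2-yl gives a number 2 percentage points higher from compound 2 to compound 3 (within the scatter), so on this read-out the two groups cannot be told apart. Stability therefore holds at this position when the ring sulfur gives way to a ring oxygen and the isobutyl group gives way to neopentyl, something that compound 1 and compound 2 could not show, as they differ in more than one place. Nothing available here explains why the two groups behave alike.

On these data alone, the ring and the chain change together, so what each contributes on its own stays open. Also open, as far as these compounds go, is whether this position keeps its stability with an amine on the ring in place of the neopentyl group, or with a longer chain.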